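Adding a bromo to compound 3

This account rests on a few compounds, and the source may have more. Where it says the series, first, only, none or still open, it means among the compounds named here.

In a functional assay on MCF7 cells (Homo sapiens) for antiproliferative activity, read by MTT assay, with a stated time of 48 h (on this read-out higher numbers stand for weaker inhibition and lower numbers for stronger inhibition), compound 3 `Clc1ccc(-c2nn(-c3ccccc3)cc2-c2nc3ccccc3[nH]2)cc1` gives 3030 nM and sits level with compound 2 `Fc1ccc(-c2nn(-c3ccccc3)cc2-c2nc3ccccc3[nH]2)cc1` at 3200 nM on this scale. Compound 1 `Brc1ccc2[nH]c(-c3cn(-c4ccccc4)nc3-c3ccccc3)nc2c1` gives 830 nM and stands lower than compound 3, beyond the scatter. Compound 4 `Clc1ccc(-c2nn(-c3ccccc3)cc2-c2nc3cc(Br)ccc3[nH]2)cc1` is compound 3 with one change, bromo in place of hydrogen on an aromatic carbon. For the measured compounds named here, the only measured single change, a 1.1-fold lower number from compound 2 to compound 3 (0.02 log units; within the scatter) for chloro in place of fluoro, stays within the scatter and does not test bromo directly. The closest hint is that the chloro of compound 3 is absent from compound 1, which also carries a bromo, and compound 1 at 830 nM suggests that the bromo may lower the number. This evidence is indirect, so a moderate move towards stronger inhibition is expected, a 2.8-fold lower number from compound 3 to compound 4 (0.44 log units; beyond the scatter) as the estimated step. The number for compound 4 is estimated at 1100 nM within an expected range of 350 nM to 3300 nM in this assay when measured.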

Compound 4, half-maximal inhibitory concentration: 1920 nM
Estimate against measurement, compound 4: 1.7-fold (0.24 log units) below; the measured number falls inside the stated range.
By their numbers in this assay, from the lowest: compound 1; then compounds 4, 3 and 2 (each within the scatter of the next).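

On this aromatic carbon, bromo in place of hydrogen can now be judged directly in this assay: a 1.6-fold lower number from compound 3 to compound 4 (0.20 log units; within the scatter) stays within the scatter, so with the chloro present, the bromo makes no clear difference. The chloro step, in contrast, gives a 2.3-fold higher number from compound 1 to compound 4 (0.36 log units; beyond the scatter), a modest change beyond the scatter, so with the bromo present, the compound without the chloro shows the stronger inhibition, and the bromo alone does not account for the low number of compound 1. Nothing measured here explains either result.

As far as these compounds go, it remains open whether a different group on the same carbon, such as an amine or a carboxylic acid, would shift the number beyond the scatter. From the compounds shown here alone, it is also open whether the chloro step would be similar without the bromo on the core.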